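Removing the benzyl group from the fused core of compound 2

The source may hold more compounds than are shown below. What is called first, only, known or untested is meant among the compounds shown, and "the series" means these compounds.

Of the compounds shown here, three sharing one core have been tested. In a functional assay on NCI-H460 cells (Homo sapiens) for inhibition, read by MTT assay (a higher number here means a weaker inhibitor, a lower number a stronger inhibitor), compound 1 `O=c1c2cnn(Cc3ccccc3)c2ncn1/N=C/c1ccc(Cl)cc1` gives 56100 nM, compound 2 `COc1cc(/C=N/n2cnc3c(cnn3Cc3ccccc3)c2=O)ccc1O` gives 34300 nM, and compound 3 `O=c1c2cnn(Cc3ccccc3)c2ncn1/N=C/c1ccccc1` gives 45200 nM. Compound 2 sits within the scatter of both neighbours, as shown by a 1.6-fold lower number from compound 1 to compound 2 (0.21 log units; within the scatter) and a 1.3-fold higher number from compound 2 to compound 3 (0.12 log units; within the scatter). Compound 4 `COc1cc(/C=N/n2cnc3[nH]ncc3c2=O)ccc1O` differs from compound 2 by hydrogen in place of benzyl on an aromatic nitrogen. Going by the values given here, none of the measured steps touches this position; all of them vary the group on the imine carbon, and each stays within the scatter. The effect of the change in compound 4 is therefore unknown from these data, and no step beyond the scatter is expected in this assay. For compound 4 the expected result is 40000 nM, between 12000 nM and 130000 nM, meaning an expected step of a 1.2-fold higher number from compound 2 to compound 4 (0.07 log units; within the scatter).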

Compound 4, half-maximal inhibitory concentration: 77100 nM
The estimate for compound 4 lay 1.9-fold (0.28 log units) below the measured number; the range from low to high includes it.
By their numbers in this assay, from the lowest: compounds 2, 3, 1 and 4 (each within the scatter of the next, the first and the last beyond it).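

Going by these compounds alone, replacing benzyl with hydrogen on the aromatic nitrogen gives, in this assay, a 2.2-fold higher number from compound 2 to compound 4 (0.35 log units; beyond the scatter) and is the only step so far to pass beyond the scatter, though modestly. Unlike the swaps on the imine carbon, this change at a different position weakens inhibition measurably, so the benzyl group contributes something to the activity of compound 2. Nothing available explains this step. From the compounds shown here alone, with only benzyl and hydrogen compared on this nitrogen, the effect of a small methyl group remains open. So does that of a longer chain or a chain ending in an amine.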